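This account rests on a few compounds, and the source may have more. Where it says the series, first, only, none or still open, it means among the compounds named here.

Of the compounds shown here, three sharing one core have been measured in a functional assay on MOLT-4 cells (Homo sapiens) for inhibition; a lower number here means a stronger inhibitor, a higher number a weaker inhibitor. Compound 1 `O=C1O/C(=C\Cn2cc(C(F)(F)F)c(=O)[nH]c2=O)C(OCc2ccccc2)=C1OCc1ccccc1`, carrying trifluoromethyl, gives 900 nM. Compound 2 `O=C1O/C(=C\Cn2ccc(=O)[nH]c2=O)C(OCc2ccccc2)=C1OCc1ccccc1`, carrying hydrogen instead, gives 4800 nM, and compound 3 `O=C1O/C(=C\Cn2cc(Br)c(=O)[nH]c2=O)C(OCc2ccccc2)=C1OCc1ccccc1`, carrying bromo, gives 3900 nM. Compound 3 thus stands with compound 2 and apart from compound 1, the two steps being a 1.2-fold lower number from compound 2 to compound 3 (0.09 log units; within the scatter) and a 4.3-fold higher number from compound 1 to compound 3 (0.64 log units; beyond the scatter).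

Compound 4 `O=C1O/C(=C\Cn2cc(F)c(=O)[nH]c2=O)C(OCc2ccccc2)=C1OCc1ccccc1` alters one group of compound 3: fluoro in place of bromo on an aromatic carbon. Going by the values given here, no measured step covers this exchange directly. Bromo in place of hydrogen moved the number only within the scatter, as a 1.2-fold lower number from compound 2 to compound 3 (0.09 log units; within the scatter) shows, while the modest steps of a 5.3-fold higher number from compound 1 to compound 2 (0.73 log units; beyond the scatter) and a 4.3-fold higher number from compound 1 to compound 3 (0.64 log units; beyond the scatter) both involve the loss of trifluoromethyl, the only fluorine-bearing group so far. A small move toward a lower number is therefore expected, possibly not beyond the scatter. The estimated step is a 1.6-fold lower number from compound 3 to compound 4 (0.19 log units; within the scatter). Compound 4 is expected to give 2500 nM, with an estimated range of 700 nM to 6000 nM.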

Compound 4, half-maximal inhibitory concentration: 10900 nM
Estimate against measurement, compound 4: 4.4-fold (0.64 log units) below, outside the stated range (above it).
By their numbers in this assay, from the lowest: compound 1; then compounds 3 and 2 (each within the scatter of the next); then compound 4.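

Fluoro and bromo do not behave alike at this position in this assay, with a 2.8-fold higher number from compound 3 to compound 4 (0.45 log units; beyond the scatter), even though bromo and hydrogen had stayed within the scatter of each other. Fluoro also parts from hydrogen, with a 2.3-fold higher number from compound 2 to compound 4 (0.36 log units; beyond the scatter), so compound 4 has the highest number of the four and is the weakest inhibitor shown. The span at this one position also widens to a 12-fold higher number from compound 1 to compound 4 (1.08 log units; beyond the scatter), which puts the two fluorine-bearing groups at opposite ends of the series and shows that the presence of fluorine alone does not set the order. From the compounds shown here alone, how chloro, methyl, a nitrile or an amine on this carbon would place relative to these four compounds remains open. No measurement is at hand that explains why these groups differ.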